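The source may report more compounds than this note shows. Statements on the series, on what has been measured and on what is new or still open speak of the compounds shown alone.

Measured so far in a toxicity assay on MT4 cells (Homo sapiens) for cytotoxicity, read by MTT assay (on this read-out lower numbers stand for higher toxicity in this test and higher numbers for lower toxicity in this test), are two compounds:
- compound 1 `Cc1ccc(-c2cc(C)c(Oc3cc(N)nc(Nc4ccc(C#N)cc4)n3)c(C)c2)cc1` at 10000 nM in this read-out
- compound 2 `COc1ccccc1-c1cc(C)c(Oc2cc(N)nc(Nc3ccc(C#N)cc3)n2)c(C)c1` at 21800 nM in this read-out

Compound 2 holds the higher of these two numbers. For the measured compounds named here, compound 3 `Cc1cc(-c2ccc(C#N)c(C#N)c2)cc(C)c1Oc1cc(N)nc(Nc2ccc(C#N)cc2)n1` has 3,4-dicyanophenyl in place of 2-methoxyphenyl on an aromatic carbon as its one change. Going by the values given here, the only measured step bearing on this swap is a 2.2-fold higher number from compound 1 to compound 2 (0.34 log units; beyond the scatter) and it was modest. A step of similar modest size is therefore expected in this assay and, with compound 2 at the top of the range so far, the expected direction is downward, as a 2.2-fold lower number from compound 2 to compound 3 (0.34 log units; beyond the scatter) in this estimate. For compound 3 the estimated value is 10000 nM within a range of 3000 nM to 30000 nM as expected here.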

Compound 3, half-maximal cytotoxic concentration: 17600 nM
Compound 3: the middle estimate sits 1.8-fold (0.25 log units) below what was measured; the measured number falls inside the stated range.
By their numbers in this assay, from the lowest: compounds 1, 3 and 2 (each within the scatter of the next, the first and the last beyond it).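

In this assay the swap to 3,4-dicyanophenyl gives a 1.2-fold lower number from compound 2 to compound 3 (0.09 log units; within the scatter) and a 1.8-fold higher number from compound 1 to compound 3 (0.25 log units; within the scatter) with both steps within the scatter. This position therefore takes a phenyl group carrying two nitriles, and the read-out does not separate that group from either 2-methoxyphenyl or 4-methylphenyl, although those two stand apart beyond the scatter. No evidence at hand accounts for this result. The compounds shown leave open whether a group without an aromatic ring here, such as an amine or a carboxylic acid, would shift the number beyond the scatter.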